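Cyclopropane Linker Swap in a Cytotoxicity Series

The source may hold more compounds than are shown below. What is called first, only, known or untested is meant among the compounds shown, and "the series" means these compounds.

Of the compounds shown here, two sharing one core have been measured in an ADME assay on MT2 cells (Homo sapiens) for cytotoxicity, read by XTT assay, with a stated time of 4 days; on this read-out lower numbers stand for higher toxicity in this test and higher numbers for lower toxicity in this test. Compound 1, `Cc1nc2c(c(-c3cc(F)c4c(c3C)CCCO4)c1[C@H](OC(C)(C)C)C(=O)O)CN(CCCc1ccccc1)CC2`, gave only a limit of the assay, > 40000 nM. Compound 2, `Cc1nc2c(c(-c3cc(F)c4c(c3C)CCCO4)c1[C@H](OC(C)(C)C)C(=O)O)CN(CCCc1ccncc1)CC2`, likewise reached only a limit of the assay, > 40000 nM. The step that the two limits leave unreadable from compound 1 to compound 2 therefore cannot be sized, because of the limit of > 40000 nM in this assay, at which 2 of the 2 values shown sit. On the numbers shown, compound 2 stands at that limit, and nothing finer is known about it.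

Compound 3, `Cc1nc2c(c(-c3cc(F)c4c(c3C)CCCO4)c1[C@H](OC(C)(C)C)C(=O)O)CN(CC1CC1c1ccccc1)CC2`, is the next compound and has not yet been measured in this assay. Its change from compound 2 is 2-phenylcyclopropyl in place of 2-(pyridin-4-yl)ethyl on a saturated chain carbon bound to an amine nitrogen in a ring. For the measured compounds named here, only one measured step exists; it sits at the same amine nitrogen in a ring, yet its size is not readable, so it gives no direction for this assay. The expectation is therefore that compound 3 stays where compound 2 stands, with an expected step of a number no higher from compound 2 to compound 3 (the limit leaves the size open) that does not go beyond the scatter. Compound 3 is thus estimated at 40000 nM, within 15000 nM to 100000 nM, most probably reported again only as a limit.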

Compound 3, half-maximal cytotoxic concentration: > 40000 nM
Compound 3: no number, only a limit; the forecaster's own chance of this, stated with the estimate: 80%; the middle value sits exactly at the limit.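

In this assay compound 3 gives > 40000 nM, which is again a limit of the assay and not a number. For the compounds shown here, no step among compound 1, compound 2 and compound 3 can be read, because all three share one limit: the limit of > 40000 nM in this assay, at which 3 of the 3 values shown sit. Left open is whether these three compounds differ in toxicity at all, and whether any group on the amine nitrogen in a ring would give a number rather than a limit.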